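Swapping Methyl for Bromo on Compound 1

A few compounds are considered here, and "the series" means these few. Any claim that something is new, unique, unknown or untested is made for them only; others in the source may bear on it.

Among the measured compounds shown here, in a functional assay on A549 cells (Homo sapiens) for antiproliferative activity, read by MTT assay, with a stated time of 48 h (on this read-out lower numbers stand for stronger inhibition and higher numbers for weaker inhibition), compound 1 `Cc1ccc(-c2nnc(NC(=O)/C=C/c3ccc(C(F)(F)F)cc3)s2)cc1` gives 1.61 ug/mL, the higher of the two numbers measured so far, which makes it the weaker inhibitor of the pair. Compound 2 `COc1ccc(/C=C/C(=O)Nc2nnc(-c3ccc(C)cc3)s2)cc1` gives 0.66 ug/mL. The next molecule, compound 3 `O=C(/C=C/c1ccc(C(F)(F)F)cc1)Nc1nnc(-c2ccc(Br)cc2)s1`, is compound 1 with a single change: bromo in place of methyl on an aromatic carbon. Put simply, 4-methylphenyl becomes 4-bromophenyl.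

For the measured compounds named here, only one measured step offers any guidance: a 2.4-fold lower number from compound 1 to compound 2 (0.39 log units; beyond the scatter), with methoxy in place of trifluoromethyl on an aromatic carbon. That step is modest and leaves the methyl untouched. It shows how far one small swap has moved the number in this pair, but it says nothing about which way a bromo swap will go. Going by the values given here, no measurement yet compares methyl with bromo. The expectation in this assay is no step beyond the scatter, though a modest move in either direction remains possible. Compound 3 is expected at 1.5 ug/mL, with an estimated range of 0.6 ug/mL to 3.8 ug/mL. This expected value means a 1.1-fold lower number from compound 1 to compound 3 (0.03 log units; within the scatter).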

Compound 3, half-maximal inhibitory concentration: 4.68 ug/mL
Estimate against measurement, compound 3: 3.1-fold (0.49 log units) below; measured number outside the range, above it.
By their numbers in this assay, from the lowest: compound 2; then compound 1; then compound 3.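

The 4-methylphenyl end of the molecule proves to matter: in this assay, bromo in place of methyl gives a 2.9-fold higher number from compound 1 to compound 3 (0.46 log units; beyond the scatter), so inhibition becomes weaker. Among the compounds shown here, the only earlier step replaced trifluoromethyl with methoxy and left the methyl untouched, so this is the first reading of any change at this position, on an aromatic carbon para to a large group. It shows that exchanging one heavy atom for another here, with no hydrogen-bond donor or acceptor on either side and no net charge, is enough to move the number beyond the usual scatter, although nothing available explains the shift.

As far as these compounds go, a single step cannot show how other groups would behave at this position, so it remains open how an amine, a carboxylic acid or a longer alkyl chain would read in this assay. From the compounds shown here alone, it also remains open whether bromo in place of methyl would shift the number in the same direction and by a similar amount on compound 2 , which carries methoxy where compound 1 has trifluoromethyl.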